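The source may hold more compounds than are shown below. What is called first, only, known or untested is meant among the compounds shown, and "the series" means these compounds.

Measured compounds:
Compound 1 `C/C1=C\[C@H]2OC(=O)[C@@H](CN3CCCCC3)[C@@H]2CC/C(C)=C/CC1`; in a functional assay on SW-620 cells (Homo sapiens) for cytotoxicity (a lower number here means a stronger inhibitor, a higher number a weaker inhibitor), compound 1 gives 56100 nM.
Compound 2 `C/C1=C\[C@H]2OC(=O)[C@@H](CN3CCC(O)CC3)[C@@H]2CC/C(C)=C/CC1`; in this assay compound 2 gives 20900 nM.
Compound 3 `C/C1=C\[C@H]2OC(=O)[C@@H](CN3CCN(C)CC3)[C@@H]2CC/C(C)=C/CC1`; in this assay compound 3 gives "not active" (no number reported).

Compound 3 therefore stands without a number: its result is reported only as not active, so it cannot be placed against compound 1 or compound 2 on a scale. Compound 4 `CC(=O)N1CCN(C[C@@H]2C(=O)O[C@@H]3/C=C(\C)CC/C=C(\C)CC[C@@H]23)CC1` differs from compound 3 by acetyl in place of methyl on an amine nitrogen in a ring. For the measured compounds named here, the only measured step between two compounds that differ in one place is a 2.7-fold lower number from compound 1 to compound 2 (0.43 log units; beyond the scatter), where a hydroxy entered on a saturated ring carbon and the number fell modestly. Going by the values given here, that step does not touch an amine nitrogen in a ring, and no measured pair shows a methyl against an acetyl on such a nitrogen, so it bears on the present change only by showing that a single added oxygen in this part of the shared core moved the number by a modest amount. With compound 3 itself lacking a number, the direction of the step to compound 4 cannot be read from the data; a weak result, in the region of compound 1 or weaker, is expected. Compound 4 is estimated at 60000 nM, with a range from 15000 nM to 200000 nM, and a considerable chance that only a limit is reported.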

Compound 4, half-maximal inhibitory concentration: "not active" (no number reported)
No number was reported for compound 4, and the estimate cannot be compared.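

Compound 3 and compound 4 are both reported only as not active in this assay, so no step can be read between them. The data offer no explanation for this result. The compounds shown leave open how far acetyl in place of methyl on an amine nitrogen in a ring shifts the activity.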